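Working notes: methyl ester to free acid, compound 1 to compound 3

The source may report more compounds than this note shows. Statements on the series, on what has been measured and on what is new or still open speak of the compounds shown alone.

Compound 1 `C=CCC/C=C\C=C/CCCCCCCC[C@@H]1CC[C@@H]([C@@H]2CC[C@@H](CC(=O)OC)OO2)O1` is the methyl ester of the series. In a functional assay on DU-145 cells (Homo sapiens) for cytotoxicity (a higher number here means a weaker inhibitor, a lower number a stronger inhibitor), compound 1 gives 0.1 ug/mL. Compound 2 `C=CCCC/C=C/C=C\CCCCCCCC[C@H]1CC[C@@H]([C@H]2CC[C@@H](CC(=O)O)OO2)O1` carries the free carboxy group on a core of differing configuration; in this assay compound 2 gives 0.1 ug/mL. Compound 1 stands level with compound 2 at the digits shown, within the scatter of the half-maximal inhibitory concentration. Among the compounds with values here, no pair of measured compounds differing in a single place is available, so no measured step size exists in this assay.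

Compound 3 `C=CCC/C=C\C=C/CCCCCCCC[C@@H]1CC[C@@H]([C@@H]2CC[C@@H](CC(=O)O)OO2)O1` is the unmeasured target. It differs from compound 1 in one place: hydrogen in place of methyl on an oxygen next to a carbonyl group, that is methoxycarbonyl to carboxy, the same replacement that separates compound 1 from compound 2 apart from configuration. Given compound 1 at 0.1 ug/mL and the level value of compound 2 at 0.1 ug/mL, the expected step is no change at the digits printed from compound 1 to compound 3 (within the scatter), none beyond the scatter. Compound 3 is therefore estimated at 0.1 ug/mL, within 0.04 ug/mL to 0.3 ug/mL.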

Compound 3, half-maximal inhibitory concentration: 0.1 ug/mL
Compound 3: the middle estimate sits on the measured number at the digits printed; measured number inside the range.
By their numbers in this assay, from the lowest: compounds 1, 2 and 3 (each within the scatter of the next).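

Within the data shown here, the reading no change at the digits printed from compound 1 to compound 3 (within the scatter) is the first single-place step in this assay, and it isolates hydrogen in place of methyl on an oxygen next to a carbonyl group from any difference in configuration. On the core of compound 1, this assay does not separate the methoxycarbonyl group from the carboxy group, so the terminal methyl is not needed to keep the reading at this level. No measurement on hand explains why the two forms read alike.

Going by these compounds, whether an amide, a primary alcohol or a longer ester in place of the methoxycarbonyl group would read the same remains open. Also open, on these data alone, is whether the methyl ester of compound 2 would stand level with compound 2 on that differing configuration.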